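The compounds below may be only part of what the source reports. "The series", "measured", "known", "first", "only" and "open" are said of these compounds alone.

The measured compounds:

Compound 1, `COc1ccc(C(=O)/C=C\Nc2ccc(-c3nc4cc(OC)c(OC)c(OC)c4s3)cc2C)cc1O`: in a functional assay on MDA-MB-231 cells (Homo sapiens) for antiproliferative activity, read by sulforhodamine B assay, with a stated time of 48 h (on this read-out lower numbers stand for stronger inhibition and higher numbers for weaker inhibition), compound 1 gives 12400 nM.
Compound 2, `COc1ccc(C(=O)/C=C\Nc2ccc(-c3nc4cc(OC)c(OC)c(OC)c4s3)cc2)cc1O`: in this assay compound 2 gives 18100 nM.
Compound 3, `COc1cc(OC)c2sc(-c3ccc(N/C=C\C(=O)c4cc(OC)c(OC)c(OC)c4)c(C)c3)nc2c1`: in this assay compound 3 gives 13800 nM.

All three numbers lie close together, and none of the gaps between them is larger than the scatter of repeated measurements, so no ordering among them can be claimed.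

Compound 1 and compound 2 differ in one place only: hydrogen in place of methyl on an aromatic carbon. The step this made in this assay was a 1.5-fold higher number from compound 1 to compound 2 (0.16 log units; within the scatter), a small change that does not stand out from the scatter.

Compound 3 carries a core that differs from the core of compound 1; the difference between the two cores is not broken down here. Compound 4, `COc1cc(OC)c2sc(-c3ccc(N/C=C\C(=O)c4cc(OC)c(OC)c(OC)c4)cc3)nc2c1`, has not yet been measured in this assay. It differs from compound 3 in one place: hydrogen in place of methyl on an aromatic carbon. The words describing the place of this change are the same as for the step from compound 1 to compound 2, so it is the same change on a different core.

Because a 1.5-fold higher number from compound 1 to compound 2 (0.16 log units; within the scatter) was small, the corresponding step on the core of compound 3 is expected to be small as well, and the expected step is a 1.4-fold higher number from compound 3 to compound 4 (0.14 log units; within the scatter). For compound 4 the expected value in this assay is 19000 nM, with the likely range estimated to run from 9000 nM to 40000 nM.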

Compound 4, half-maximal inhibitory concentration: 15800 nM
Compound 4: the middle estimate sits 1.2-fold (0.08 log units) above what was measured; measured number inside the range.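

Taking the methyl off the aromatic carbon on the core of compound 3 left the number in this assay practically where it was, with a 1.1-fold higher number from compound 3 to compound 4 (0.06 log units; within the scatter). Set beside the earlier case, the two steps agree, and no difference between the cores can be claimed: the same change on two cores in this assay, a 1.5-fold higher number (0.16 log units; within the scatter) from compound 1 to compound 2 and a 1.1-fold higher number (0.06 log units; within the scatter) from compound 3 to compound 4, 1.3-fold (0.11 log units) apart, within the scatter of two such steps. This shows that, for these two cores and this one read-out, hydrogen in place of methyl gave a small step both times, so the small step seen on one core was a fair guide to the other, but it does not show that the methyl contributes anything, since neither step stands out from the scatter, and two cores are too few to support a rule for the whole series.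

The compounds shown hold only methyl or hydrogen at this place, so it remains open whether a different group there, such as a fluorine, an amine, a carboxylic acid or a longer chain, would move the number by more than the scatter. Going by these compounds, it also remains open whether the change would stay this small on a core that gives much lower numbers, or in another cell line.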